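The source may hold more compounds than are shown below. What is called first, only, known or untested is meant among the compounds shown, and "the series" means these compounds.

Measured compounds:
Compound 1 `Cc1cn(C2CC(N=[N+]=[N-])C(COC(=O)OCCCCCCCCO)O2)c(=O)[nH]c1=O` — in a functional assay on MT4 cells (Homo sapiens) for cytotoxicity (a lower number here means that less compound is tolerated, a higher number that more compound is tolerated), compound 1 gives > 50000 nM, a limit of the assay.
Compound 2 `Cc1cn(C2CC(N=[N+]=[N-])C(COC(=O)NCCCC(=O)OC(C)(C)C)O2)c(=O)[nH]c1=O` — in this assay compound 2 gives > 50000 nM, also a limit.
Compound 3 `Cc1cn(C2CC(N=[N+]=[N-])C(COC(=O)OCCCC(=O)OC(C)(C)C)O2)c(=O)[nH]c1=O` — in this assay compound 3 gives > 50000 nM, again a limit.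

Compound 3 stands only at a limit in this assay, and the two further values shown are limits as well: the limit of > 50000 nM in this assay, at which 3 of the 3 values shown sit. For the measured compounds named here, the one single-point step among the measured compounds is a step that the two limits leave unreadable from compound 1 to compound 3, and the two limits leave its size unreadable. That measured step covers a related exchange, tert-butoxycarbonyl in place of 5-hydroxypentyl, so it bears on the question but gives no number.

Compound 4 `Cc1cn(C2CC(N=[N+]=[N-])C(COC(=O)OCCCCCCO)O2)c(=O)[nH]c1=O` is not yet measured. It differs from compound 3 by 3-hydroxypropyl in place of tert-butoxycarbonyl on a saturated chain carbon, three bonds along the chain from an oxygen next to a carbonyl group. With every value shown sitting at a limit, no step beyond the scatter is expected from compound 3 to compound 4, a step that the limit leaves unreadable from compound 3 to compound 4, and a further limit is the likely outcome. Compound 4 is estimated at 80000 nM in this assay, with a range of 40000 nM to 200000 nM.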

Compound 4, half-maximal cytotoxic concentration: > 50000 nM
Compound 4 ended at the assay's limit (the forecaster's own chance of this, stated with the estimate: 85%); the middle value is on the limit's open side.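

In this assay compound 4 gives > 50000 nM, a limit of the assay. No step can be read from compound 1 or compound 3 to compound 4: the limit of > 50000 nM in this assay, at which 4 of the 4 values shown sit.

The compounds shown leave open how the cytotoxic concentrations of these compounds compare, as none has a value short of this limit.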